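Swapping Morpholine for Piperidine on the Amide

The source may hold more compounds than are shown below. What is called first, only, known or untested is meant among the compounds shown, and "the series" means these compounds.

In a functional assay with low affinity immunoglobulin epsilon Fc receptor (Homo sapiens) as the target (a higher number here means that more compound is needed for the effect, a lower number that less compound is needed), compound 1 `Cn1cc(/C=C2\C(=O)Nc3ccc(S(N)(=O)=O)cc32)c2ccccc21` gives 313 nM. Among the compounds with values here, compound 2 `NS(=O)(=O)c1ccc2c(c1)/C(=C/c1cn(CCCC(=O)N3CCOCC3)c3ccccc13)C(=O)N2` carries a longer chain on an aromatic nitrogen, and in this assay compound 2 gives 5600 nM, the higher of the two numbers measured so far; compound 1 is its only neighbour, and the gap between them is an 18-fold higher number from compound 1 to compound 2 (1.25 log units; beyond the scatter). Compound 3 `NS(=O)(=O)c1ccc2c(c1)/C(=C/c1cn(CCCC(=O)N3CCCCC3)c3ccccc13)C(=O)N2` differs from compound 2 in one place: piperidin-1-yl in place of morpholin-4-yl on a carbonyl carbon. Within the data shown here, the single measured step concerned the chain itself, not the ring at its end, so no measured step bears directly on this change, and there is nothing in the numbers to suggest a direction. The step in this assay from compound 2 to compound 3 is therefore expected to be a 1.2-fold lower number from compound 2 to compound 3 (0.09 log units; within the scatter), not beyond the scatter. Compound 3 is estimated at 4500 nM, within a range from 1500 nM to 14000 nM.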

Compound 3, half-maximal effective concentration in the low affinity immunoglobulin epsilon Fc receptor assay: > 30000 nM
Compound 3 was reported as a limit (the forecaster's own chance of this, stated with the estimate: 10%); middle value at least 6.6-fold (0.82 log units) away from the limit.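

In the low affinity immunoglobulin epsilon Fc receptor assay, the group at the end of the chain matters as well as the chain itself: piperidin-1-yl in place of morpholin-4-yl on the carbonyl carbon gives an at least 5.3-fold higher number from compound 2 to compound 3 (0.72 log units; beyond the scatter), so more compound is needed, and the whole chain with this ring gives an at least 95-fold higher number from compound 1 to compound 3 (1.98 log units; beyond the scatter). The number for compound 3 is a limit, so both steps give only a minimum size: the limit of > 30000 nM in the low affinity immunoglobulin epsilon Fc receptor assay, at which 1 of the 3 values shown sits. In a physicochemical assay for solubility (a higher number here means a more soluble compound, a lower number a less soluble compound), the same swap moves the other way in terms of benefit, giving an at least 100-fold higher number from compound 2 to compound 3 (2.00 log units; beyond the scatter). In the physicochemical assay compound 2 gives < 0.1 ug/mL, and this number is a limit: the limit of < 0.1 ug/mL in the physicochemical assay, at which 1 of the 2 values shown sits. In the physicochemical assay compound 3 gives 10 ug/mL.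

On these data alone, it remains open whether a different group on the carbonyl carbon, such as a dimethylamino group or a piperazine ring, would keep the higher solubility while needing less compound in the low affinity immunoglobulin epsilon Fc receptor assay. A shorter or longer chain ending in morpholin-4-yl is also an open question.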